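From a Fluorinated Ether to an Acetate Ester

The source may report more compounds than this note shows. Statements on the series, on what has been measured and on what is new or still open speak of the compounds shown alone.

Compound 3 `CCc1cccc2c(OC)c(-c3occ(C)c3COCC(F)(F)F)ccc12` is the weaker of the two compounds in this set that return a number. In a functional assay on KBVIN cells (Homo sapiens) for cytotoxicity, read by MTT assay, with a stated time of 72 h (on this read-out lower numbers stand for an effect already at smaller amounts and higher numbers for an effect only at larger amounts of compound), compound 3 gives 6 ug/mL, the highest of the two numbers shown. Its nearest neighbour, compound 1 `CCc1cccc2c(OC)c(-c3occ(C)c3C(=O)OC)ccc12`, carries methoxycarbonyl on the same aromatic carbon, and in this assay compound 1 gives 1.3 ug/mL; the step of a 4.6-fold higher number from compound 1 to compound 3 (0.66 log units; beyond the scatter). The remaining compound, compound 2 `CCc1cccc2c(OC(C)=O)c(-c3occ(C)c3COC(C)=O)ccc12`, is recorded in this assay only as a limit, > 10 ug/mL, which is the limit of > 10 ug/mL in this assay, at which 1 of the 3 values shown sits.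

Compound 4 `CCc1cccc2c(OC)c(-c3occ(C)c3COC(C)=O)ccc12` differs from compound 3 in one place: acetyl in place of 2,2,2-trifluoroethyl on an oxygen on a saturated carbon. Compound 4 thus keeps the methoxy of compound 3 while taking on the acetoxymethyl of compound 2. Among the compounds with values here, the only measured step at this position, a 4.6-fold higher number from compound 1 to compound 3 (0.66 log units; beyond the scatter), was modest and concerns the exchange of the whole side chain, not the acetyl. Within the data shown here, compound 2 shares the acetoxymethyl with compound 4 but differs from it in a second place too, so no single step can be drawn from it.

For compound 4 the expected value in this assay is 8 ug/mL, with a range from 3 ug/mL to 20 ug/mL. The estimated step of a 1.3-fold higher number from compound 3 to compound 4 (0.12 log units; within the scatter) stays within the scatter, and a limit rather than a number remains a real possibility for compound 4.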

Compound 4, concentration for half-maximal effect: > 10 ug/mL
Compound 4 gave a limit, no number; the forecaster's own chance of this, stated with the estimate: 35%; middle value at least 1.2-fold (0.09 log units) from the limit.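

Compound 4 is recorded in this assay only as a limit, so the methoxy of compound 3 on the shared core does not by itself bring a number back once acetoxymethyl sits on the aromatic carbon, and compound 2 and compound 4 now share that limit: the limit of > 10 ug/mL in this assay, at which 2 of the 4 values shown sit.

Against the methoxycarbonyl of compound 1, the exchange on that aromatic carbon gives an at least 7.6-fold higher number from compound 1 to compound 4 (0.88 log units; beyond the scatter), which makes acetoxymethyl the second side chain, after (2,2,2-trifluoroethoxy)methyl, to fall behind the methoxycarbonyl. The change on the oxygen on a saturated carbon gives an at least 1.6-fold higher number from compound 3 to compound 4 (0.22 log units; that floor lies within the scatter), so this floor does not separate acetyl from 2,2,2-trifluoroethyl, and the step between the two limits cannot be read.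

Going by these compounds, whether acetyl and 2,2,2-trifluoroethyl truly differ in this assay therefore remains open. Also open, on these data alone, is what a carboxylic acid, a primary amide or a hydroxymethyl on the same aromatic carbon would give, and whether any of them would match the methoxycarbonyl of compound 1.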